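The source may hold more compounds than are shown below. What is called first, only, known or untested is meant among the compounds shown, and "the series" means these compounds.

Measured so far in a functional assay on SF-295 cells (Homo sapiens) for inhibition, read by sulforhodamine B assay, with a stated time of 48 h, tested at 10 uM; on this read-out higher numbers stand for more inhibition at the one concentration tested (going by the name of the read-out) and lower numbers for less inhibition:
- Compound 1 `CCc1ccc(-c2cn3ccnc3c(-c3ccc4ncn(Cc5ccccc5)c4c3)n2)cc1` gives 51.2%.
- Compound 2 `O=Cc1ccc(-c2cn3ccnc3c(-c3ccc4ncn(Cc5ccccc5)c4c3)n2)cc1` gives 23.1%.

Among the measured compounds shown here, compound 2 stands lowest of the two; the only step measured is a number 28.1 percentage points lower from compound 1 to compound 2 (beyond the scatter), a drop that lies beyond the scatter. Compound 3 `c1ccc(Cn2cnc3ccc(-c4nc(-c5cccc6ccccc56)cn5ccnc45)cc32)cc1` differs from compound 2 by naphthalen-1-yl in place of 4-formylphenyl on an aromatic carbon. For the measured compounds named here, the one measured step sits at the same place and shows that removing the ethyl for a formyl there cost inhibition; going from compound 2 to compound 3 removes the formyl again, so an upward step of a number 21.9 percentage points higher from compound 2 to compound 3 (beyond the scatter) is expected, though no naphthalenyl analogue has been measured. Compound 3 is therefore estimated at 45%, in the range 20% to 70%.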

Compound 3, a percentage reported as inhibition, at one concentration (the size of the read-out at that concentration, not a potency): 8.22%
Beside the measured number, compound 3's estimate is 36.8 percentage points above it; the measured number lies below the stated range.
By their numbers in this assay, from the lowest: compound 3; then compound 2; then compound 1.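

In this assay, naphthalen-1-yl at this aromatic carbon next to the ring nitrogen gives a number 14.9 percentage points lower from compound 2 to compound 3 (beyond the scatter) and, against the 4-ethylphenyl, a number 43 percentage points lower from compound 1 to compound 3 (beyond the scatter) as well. Losing the formyl therefore does not by itself restore inhibition here, and with an all-carbon aromatic group of two rings the number is lower than with either single phenyl ring. Nothing available explains this drop.

On these data alone, whether a longer chain in place of the ethyl would hold the number remains open. So does whether an amine or a carboxylic acid on the phenyl ring, or naphthalen-2-yl, would do so.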